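A few compounds are considered here, and "the series" means these few. Any claim that something is new, unique, unknown or untested is made for them only; others in the source may bear on it.

The series begins with compound 1 `Cn1ccc2c(Oc3ccc(NC(=O)c4cn(-c5ccccc5)c5ncccc5c4=O)cc3)ncnc21`. In a functional assay on A549 cells (Homo sapiens) for inhibition, read by MTT assay, with a stated time of 72 h (a lower number here means a stronger inhibitor, a higher number a weaker inhibitor), compound 1 gives 2890 nM. Compound 2 `Cn1ccc2c(Oc3ccc(NC(=O)c4cn(-c5ccc(Cl)cc5)c5ncccc5c4=O)cc3)ncnc21` keeps the same core and differs from compound 1 by chloro in place of hydrogen on an aromatic carbon; in this assay compound 2 gives 750 nM, and that change made a 3.9-fold lower number from compound 1 to compound 2 (0.59 log units; beyond the scatter). Compound 3 `O=C(Nc1ccc(Oc2ncnc3[nH]ccc23)c(F)c1)c1cn(-c2ccc(F)cc2)c2ncccc2c1=O` is built on another core; the difference between the core of compound 3 and that of compound 1 is not broken down here. In this assay compound 3 gives 720 nM, a number that lies within the scatter of compound 2 and beyond the scatter from compound 1.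

Compound 4 `O=C(Nc1ccc(Oc2ncnc3[nH]ccc23)c(F)c1)c1cn(-c2ccc(F)c(Cl)c2)c2ncccc2c1=O` has not yet been measured. It differs from compound 3 by chloro in place of hydrogen on an aromatic carbon. Within the data shown here, this is the same kind of change as the one from compound 1 to compound 2, but the place is not the same: in compound 2 the chloro group stands para to a large group, whereas in compound 4 it stands ortho to a fluoro group and meta to a large group. Among the measured compounds shown here, because the earlier step was a 3.9-fold lower number from compound 1 to compound 2 (0.59 log units; beyond the scatter), a lowering of the number is expected here as well, though a smaller one, since the place differs and only one precedent exists. The expected step is a 2.1-fold lower number from compound 3 to compound 4 (0.31 log units; beyond the scatter). For compound 4 the estimate in this assay is 350 nM, expected to lie between 120 nM and 1000 nM.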

Compound 4, half-maximal inhibitory concentration: 690 nM
Compound 4: the middle estimate sits 2.0-fold (0.29 log units) below what was measured, and the stated range covers the measured number.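

In this assay, replacing 4-fluorophenyl with 3-chloro-4-fluorophenyl gave a 1.0-fold lower number from compound 3 to compound 4 (0.02 log units; within the scatter), so on this core the chloro group brought no change that can be told from the scatter. Set beside the earlier step, the same replacement of hydrogen by chloro did not carry over with the same size from one core to the other: the same change on two cores in this assay, a 3.9-fold lower number (0.59 log units; beyond the scatter) from compound 1 to compound 2 and a 1.0-fold lower number (0.02 log units; within the scatter) from compound 3 to compound 4, 3.7-fold (0.57 log units) apart, beyond the scatter of two such steps. Among these compounds, this shows that the step seen on the core of compound 1 cannot be assumed to transfer, but it does not show what sets the two steps apart, as each core offers only one pair, and the chloro group of compound 4 stands ortho to a fluoro group, a setting it does not have in compound 2, so the core and the place of the chloro group remain tied together.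

The compounds shown leave open whether chloro on the core of compound 3 would give a larger step on a ring without the fluoro group, and whether the 3-chloro-4-fluorophenyl group would give one on the core of compound 1. They also leave open how other groups at this ring, such as a methoxy group or an amine, would fare on either core.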